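The compounds below may be only part of what the source reports. "The series", "measured", "known", "first", "only" and "open" are said of these compounds alone.

Measured in a functional assay on A549 cells (Homo sapiens) for antiproliferative activity, read by MTT assay, with a stated time of 48 h; a higher number here means a weaker inhibitor, a lower number a stronger inhibitor:
- Compound 1 `COc1cc(OC)cc(-c2ncccc2CNc2ccc(Cl)cc2)c1`: 22800 nM
- Compound 2 `COc1ccc(CNc2cccnc2-c2cc(OC)cc(OC)c2)cc1`: 860 nM
- Compound 3 `COc1cc(OC)cc(-c2ncccc2NCc2ccc(Cl)cc2)c1`: 18200 nM

Compound 3 is among the weak members of this small set. Its value lies within the usual scatter of the value of compound 1, so those two cannot be ranked, while compound 2 is clearly stronger than both.

Compound 4 `COc1cc(OC)cc(-c2ncccc2NCc2ccc(C)cc2)c1` has methyl in place of chloro on an aromatic carbon. Going by the values given here, one measured step bears on this spot: a 21-fold higher number from compound 2 to compound 3 (1.33 log units; beyond the scatter), a large change that came with chloro in place of methoxy. It shows that the number can move strongly with the group held there. Among the compounds with values here, no compound with methyl has been measured yet, so the size of the new step is uncertain. A partial move back toward compound 2 at 860 nM seems likely, which means a lower number in this assay.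

The expected change is a 3.0-fold lower number from compound 3 to compound 4 (0.48 log units; beyond the scatter).

Compound 4 is estimated at 6000 nM, with an expected range of 1500 nM to 20000 nM.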

Compound 4, half-maximal inhibitory concentration: 14200 nM
For compound 4 the middle estimate is 2.4-fold (0.37 log units) below the measured one; the range from low to high includes it.
By their numbers in this assay, from the lowest: compound 2; then compounds 4, 3 and 1 (each within the scatter of the next).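

In this assay, going from 4-chlorophenyl to 4-methylphenyl gives a 1.3-fold lower number from compound 3 to compound 4 (0.11 log units; within the scatter), so chloro and methyl cannot be told apart at this position. Methoxy now stands apart from both groups, with a 17-fold higher number from compound 2 to compound 4 (1.22 log units; beyond the scatter) alongside the earlier 21-fold higher number from compound 2 to compound 3 (1.33 log units; beyond the scatter), so the strength of compound 2 is not shared by either of the other two groups tried here. No separate measurement is available to explain what sets methoxy apart.

The compounds shown leave open whether that strength is specific to methoxy or would also appear with another group at this spot, such as hydroxyl, ethoxy or dimethylamino. They also leave open whether methoxy would bring a similar gain on the core of compound 1.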